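Replacing hydroxy with 2-aminophenyl in compound 3

A few compounds are considered here, and "the series" means these few. Any claim that something is new, unique, unknown or untested is made for them only; others in the source may bear on it.

compound 1 `COc1ccc(/C=C/C(=O)NO)cc1OCC(=O)Nc1ccc(Br)cc1`: 5870 nM
compound 2 `COc1ccc(NC(=O)COc2cc(/C=C/C(=O)NO)ccc2OC)cc1`: 3810 nM
compound 3 `COc1ccc(/C=C/C(=O)NO)cc1OCC(=O)Nc1ccccc1F`: 15600 nM

All three compounds were tested in a functional assay on MDA-MB-231 cells (Homo sapiens) for inhibition, read by MTT assay, with a stated time of 48 h; on this read-out higher numbers stand for weaker inhibition and lower numbers for stronger inhibition. Compound 3 has the highest number of the three and is the weakest inhibitor measured so far. Against compound 1 the measurements show a 2.7-fold higher number from compound 1 to compound 3 (0.42 log units; beyond the scatter), and against compound 2 they show a 4.1-fold higher number from compound 2 to compound 3 (0.61 log units; beyond the scatter). The remaining pair stays closer, with a 1.5-fold lower number from compound 1 to compound 2 (0.19 log units; within the scatter).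

The next compound is compound 4 `COc1ccc(/C=C/C(=O)Nc2ccccc2N)cc1OCC(=O)Nc1ccccc1F`. Its difference from compound 3 is 2-aminophenyl in place of hydroxy on an amide-type nitrogen. Within the data shown here, no measured step touches this site. All three steps exchange the aromatic group on a different amide-type nitrogen, so they offer only a gauge of how far numbers move in this small set. The largest of them, a 4.1-fold higher number from compound 2 to compound 3 (0.61 log units; beyond the scatter), is modest. Among the measured compounds shown here, the data hold no example of the hydroxy exchange itself, which leaves the direction open, and a higher number is only a weak lean. On that footing, a 1.4-fold higher number from compound 3 to compound 4 (0.15 log units; within the scatter) is the expected step, with no claim to precision. Compound 4 is estimated at 22000 nM, with an expected range of 7000 nM to 70000 nM.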

Compound 4, half-maximal inhibitory concentration: 15500 nM
Compound 4: the middle estimate sits 1.4-fold (0.15 log units) above what was measured; the measured number falls inside the stated range.
By their numbers in this assay, from the lowest: compounds 2 and 1 (each within the scatter of the next); then compounds 4 and 3 (each within the scatter of the next).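

Among these compounds, this is the first measured change at the nitrogen that carries the hydroxy group, and in this assay it gives a 1.0-fold lower number from compound 3 to compound 4 (0.00 log units; within the scatter), so the two compounds cannot be told apart on this read-out. The entering 2-aminophenyl brings a six-membered aromatic ring and seven heavy atoms where hydroxy has one, yet this larger exchange produces a smaller step than the aromatic exchange on the other amide-type nitrogen, which gave a 4.1-fold higher number from compound 2 to compound 3 (0.61 log units; beyond the scatter). For the 2-fluorophenyl series, then, the hydroxy of compound 3 is not required to hold the number in this assay, although the data give no measured basis for explaining why the two compounds read alike.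

The compounds shown leave open whether the same exchange would read alike on the 4-bromophenyl partner of compound 1 or the 4-methoxyphenyl partner of compound 2, whose numbers lie lower than that of compound 3. They also leave open how other groups on this nitrogen, such as 2-hydroxyphenyl or a simple methyl, would compare with hydroxy and 2-aminophenyl.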